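From a Hydroxyphenyl to a Fluorophenyl Substituent

The source may hold more compounds than are shown below. What is called first, only, known or untested is meant among the compounds shown, and "the series" means these compounds.

For the measured compounds named here, compound 1 `COc1cc(-n2cnc3ccc(-c4cccc(O)c4)cc32)cc(OC)c1OC` is the only compound here with a numeric reading: in a functional assay on A549 cells (Homo sapiens) for antiproliferative activity, read by MTT assay, with a stated time of 72 h (a higher number here means a weaker inhibitor, a lower number a stronger inhibitor), compound 1 gives 250 nM. Compound 2 `COc1cc(-c2ccc3ncn(-c4cc(OC)c(OC)c(OC)c4)c3c2)cc(OC)c1OC` is reported differently; in this assay compound 2 gives > 10000 nM, which is a limit of the assay and not a number. That value sits at the limit of > 10000 nM in this assay, at which 1 of the 2 values shown sits. Going by the values given here, no two measured compounds differ in a single place, so the size of a single structural step cannot be read from the measured data alone. Compound 3 `COc1cc(-n2cnc3ccc(-c4ccc(F)cc4)cc32)cc(OC)c1OC` has not yet been measured. It differs from compound 1 by 4-fluorophenyl in place of 3-hydroxyphenyl on an aromatic carbon. This change is expected to weaken compound 3 relative to compound 1 by a step beyond the usual scatter, estimated as a 6.0-fold higher number from compound 1 to compound 3 (0.78 log units; beyond the scatter). Compound 3 is therefore estimated at 1500 nM in this assay, with an expected range from 400 nM to 6000 nM.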

Compound 3, half-maximal inhibitory concentration: 6740 nM
Estimate against measurement, compound 3: 4.5-fold (0.65 log units) below; the measured number lies above the stated range.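

In this assay, for the compounds shown here, the exchange of 3-hydroxyphenyl for 4-fluorophenyl gives a 27-fold higher number from compound 1 to compound 3 (1.43 log units; beyond the scatter), a large step and the first single-place change that can be read at this aromatic carbon of the shared core. The heavy-atom count stays the same, but the entering group has no hydrogen-bond donor or acceptor, and the substituent on the phenyl ring changes in both identity and place, which this single step does not separate. Nothing shown accounts for the size of this step.

From the compounds shown here alone, it remains open whether 3-fluorophenyl or 4-hydroxyphenyl would read closer to compound 1 or to compound 3, which would show whether the atom or its place on the ring matters more. Going by these compounds, it is also open how a phenyl ring carrying an amine or a carboxylic acid would behave here.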